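Will One More Chain Carbon Change Cell Tolerance?

The source may hold more compounds than are shown below. What is called first, only, known or untested is meant among the compounds shown, and "the series" means these compounds.

- compound 1 `CCCCCCCCCCC#Cc1cn([C@@H]2O[C@H](CO)[C@@H](O)[C@@H]2O)c(=O)[nH]c1=O`: > 100 ug/mL, a limit
- compound 2 `CCCCCCCCCCCC#Cc1cn([C@@H]2O[C@H](CO)[C@@H](O)[C@@H]2O)c(=O)[nH]c1=O`: > 100 ug/mL, a limit

In a toxicity assay on cells (Fibroblast, Homo sapiens) for cytotoxicity, read by MTT assay, with a stated time of 3 days (a lower number here means that less compound is tolerated, a higher number that more compound is tolerated), compound 2 stands at > 100 ug/mL, which is a limit and not a number. The record so far is simple: the limit of > 100 ug/mL in this assay, at which 2 of the 2 values shown sit. Compound 3 `CCCCCCCCCCCCC#Cc1cn([C@@H]2O[C@H](CO)[C@@H](O)[C@@H]2O)c(=O)[nH]c1=O` changes one place in compound 2: methyl in place of hydrogen on a saturated chain carbon, ten or more bonds along the chain from a triple-bonded carbon. The same change was made once before, a step that the two limits leave unreadable from compound 1 to compound 2, so it gives no measured size. No step beyond the usual scatter is therefore expected, and the estimated step is a number no higher from compound 2 to compound 3 (the limit leaves the size open). For compound 3 the expected value is 100 ug/mL, with an estimated range of 50 ug/mL to 200 ug/mL.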

Compound 3, half-maximal cytotoxic concentration: > 100 ug/mL
Compound 3 gave a limit, no number (the forecaster's own chance of this, stated with the estimate: 85%); the middle value lies on the limit itself.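

Compound 1, compound 2 and compound 3 all give only a limit, so no step between them can be read: the limit of > 100 ug/mL in this assay, at which 3 of the 3 values shown sit.

From the compounds shown here alone, the concentration at which each compound becomes toxic in this assay, and whether lengthening the chain shifts it, stays open.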